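The source may hold more compounds than are shown below. What is called first, only, known or untested is meant among the compounds shown, and "the series" means these compounds.

Compound 2 `Nc1ccccc1NC(=O)c1ccc(CSc2cccc(F)c2)cc1` and compound 1 `Nc1ccccc1NC(=O)/C=C/c1ccc(CSc2ccc(F)cc2)cc1` share an amide-bearing core but differ in more than one place, so their two numbers can only be set side by side. In a functional assay on SMMC-7721 cells (Homo sapiens) for inhibition, read by CCK-8 assay, with a stated time of 72 h, tested at 2 uM (a lower number here means less inhibition of growth, a higher number more inhibition of growth at the concentration tested), compound 2 gives 18.6%, and in this assay compound 1 gives 18.3%; the two numbers lie within the scatter of each other, so compound 2 stands alongside compound 1 rather than apart from it. Compound 3 `Nc1ccccc1NC(=O)c1ccc(CSc2ccc(F)cc2)cc1` has not yet been measured in this assay. It differs from compound 2 in one place: 4-fluorophenyl in place of 3-fluorophenyl on a sulfur. Among the measured compounds shown here, no pair of measured compounds traces this change, so the numbers point to no direction. In this assay the expected step is a number 0.6 percentage points lower from compound 2 to compound 3 (within the scatter), nothing beyond the scatter and with no direction claimed. Compound 3 is accordingly estimated at 18%, with a range from 8% to 30%.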

Compound 3, percent growth inhibition at one concentration: 6.58%
The estimate for compound 3 lay 11.4 percentage points above the measured number; the whole stated range lies above it.
By their numbers in this assay, from the lowest: compound 3; then compounds 1 and 2 (each within the scatter of the next).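

In this assay, the change from 3-fluorophenyl to 4-fluorophenyl on a sulfur gives a number 12 percentage points lower from compound 2 to compound 3 (beyond the scatter), so the number at this position depends on where the fluorine stands on the phenyl ring. This is the first change in a single place among the compounds shown, and it makes clear that two compounds with the same atoms, joined differently, need not stand together in this assay. Nothing at hand bears on why the number moves.

The compounds shown leave open whether a plain phenyl, a 2-fluorophenyl or a 4-chlorophenyl on the same sulfur would give a number nearer that of compound 2 or that of compound 3. From the compounds shown here alone, it also remains open whether a 3-fluorophenyl would differ in the same way on the core of compound 1.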